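The source may report more compounds than this note shows. Statements on the series, on what has been measured and on what is new or still open speak of the compounds shown alone.

Compound 1, `CCCc1ccc(COC(=O)N[C@H]2CNC2=O)cc1`: 52 nM in an assay on HEK293 cells for inhibition of N-acylethanolamine-hydrolyzing acid amidase (Homo sapiens), read by fluorescence, with stated times of 10 min and 50 min; on this read-out higher numbers stand for weaker inhibition and lower numbers for stronger inhibition
Compound 2, `O=C(N[C@H]1CNC1=O)OCc1ccc(-c2cocn2)cc1`: 1880 nM in this assay

Among the two measured compounds, compound 2 stands with the higher number, its nearest neighbour being compound 1, which is a 36-fold higher number from compound 1 to compound 2 (1.56 log units; beyond the scatter) apart in the reverse direction: that single step, the exchange of propyl for 1,3-oxazol-4-yl on an aromatic carbon, made a large difference in the direction of weaker inhibition.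

Compound 3, `O=C(N[C@H]1CNC1=O)OCc1ccc(C2CCCC2)cc1`, is not yet measured. It differs from compound 2 in one place: cyclopentyl in place of 1,3-oxazol-4-yl on an aromatic carbon. For the measured compounds named here, the only measured step that bears on this is the one from compound 1 to compound 2, where a carbon-only group gave way to a ring with two hetero atoms and the number rose by a 36-fold higher number from compound 1 to compound 2 (1.56 log units; beyond the scatter). Compound 3 reverses that kind of exchange, bringing back a five-membered ring of carbon only. A step down, beyond the scatter, is therefore expected, roughly a 19-fold lower number from compound 2 to compound 3 (1.27 log units; beyond the scatter). For compound 3 the estimated value in this assay is 100 nM, with a likely range from 25 nM to 400 nM.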

Compound 3, half-maximal inhibitory concentration: 71 nM
Compound 3: the middle estimate sits 1.4-fold (0.15 log units) above what was measured; the measured number falls inside the stated range.
By their numbers in this assay, from the lowest: compounds 1 and 3 (each within the scatter of the next); then compound 2.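

Moving from 1,3-oxazol-4-yl to cyclopentyl at this position, on an aromatic carbon para to a large group, keeps the count of 5 heavy atoms yet gives a 26-fold lower number from compound 2 to compound 3 (1.42 log units; beyond the scatter) in this assay, so the number of heavy atoms alone does not set the result. Propyl and cyclopentyl cannot be told apart here, with a 1.4-fold higher number from compound 1 to compound 3 (0.14 log units; within the scatter) as the whole difference, so an open chain and a five-membered non-aromatic ring of carbon only both sit at the low end, and a ring as such does not go with the high number of compound 2. No measurement is available that explains the large gap between the aromatic ring with 2 hetero atoms and the two carbon-only groups.

The compounds shown do not separate the two things that change between 1,3-oxazol-4-yl and cyclopentyl, aromatic character and hetero atoms; phenyl, aromatic with carbon only, and tetrahydrofuranyl, non-aromatic with an oxygen, would pull them apart. Going by these compounds, how far carbon-only groups can grow here also stays open, for instance with a longer chain such as hexyl or a larger ring such as cyclohexyl.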